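A few compounds are considered here, and "the series" means these few. Any claim that something is new, unique, unknown or untested is made for them only; others in the source may bear on it.

Of the compounds shown here, three that share a core have been measured in an in vitro functional assay on cells for antagonist activity at metabotropic glutamate receptor 1 (Rattus norvegicus), read by inositol phosphate accumulation; a lower number here means a stronger inhibitor, a higher number a weaker inhibitor. Compound 1 `CC1(C)CC(=O)c2ccc(OCc3ccccc3)nc2C1` gives 21000 nM in this assay. Compound 2 `CC1(C)CC(=O)c2cc(Br)c(N3CCN(c4ccc(F)cc4)CC3)nc2C1` gives in this assay only a limit, <= 1000 nM, which is the limit of <= 1000 nM in this assay, at which 1 of the 3 values shown sits. Compound 3 `CCCNc1nc2c(cc1C#N)C(=O)CC(C)(C)C2` gives 2300 nM in this assay. Among the two numbers that are not limits, compound 3 holds the lower one, and the gap to compound 1 lies beyond the usual scatter.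

Compound 4 `CCCCNc1nc2c(cc1C#N)C(=O)CC(C)(C)C2` differs from compound 3 by methyl in place of hydrogen on a saturated chain carbon, three bonds along the chain from a nitrogen on an aromatic ring, in words methyl in place of hydrogen on a saturated chain carbon, three bonds along the chain from a nitrogen on an aromatic ring. For the measured compounds named here, no pair of measured compounds differs in a single place, so no measured step sets the size of this change. The step from compound 3 to compound 4 in this assay is expected to be small, at most at the edge of the scatter and, if anything, toward a lower number, as a 1.5-fold lower number from compound 3 to compound 4 (0.19 log units; within the scatter). For compound 4 the estimate in this assay is 1500 nM, within the range 500 nM to 5000 nM.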

Compound 4, half-maximal inhibitory concentration: 1700 nM
Compound 4: middle estimate off by 1.1-fold (0.05 log units), on the low side, within the range that was stated.
By their numbers in this assay, from the lowest: compounds 4 and 3 (each within the scatter of the next); then compound 1. At a limit, below all of these: compound 2.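

In this assay the step reads a 1.4-fold lower number from compound 3 to compound 4 (0.13 log units; within the scatter), and it is the first measured step among these compounds that differs in one place. It shows that on this saturated chain, three bonds along from a nitrogen on an aromatic ring, the change from propyl to butyl leaves the number within the scatter, so this one added methyl has no readable effect here. Nothing in the data shown bears on the reason for this result.

The compounds shown leave open whether a longer chain such as pentyl or a cyclopropylmethyl group on this nitrogen would also stay within the scatter of compound 3. They also leave open whether an amine or a carboxylic acid carried on this chain would move the number beyond it.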